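The compounds below may be only part of what the source reports. "The series", "measured", "known", "first", "only" and "open" are said of these compounds alone.

The measured compounds are three. Compound 1 `Oc1ccc(-c2cc(-c3cccc(F)c3)cc(-c3ccccc3O)n2)cc1` in a functional assay on HCT-15 cells (Homo sapiens) for inhibition (on this read-out lower numbers stand for stronger inhibition and higher numbers for weaker inhibition), gives > 50000 nM, which is a limit of the assay and not a number. Compound 2 `Oc1ccc(-c2cc(-c3ccc(F)cc3)cc(-c3ccccc3O)n2)cc1` in this assay gives > 50000 nM, again a limit rather than a number. For the measured compounds named here, compound 3 `Oc1ccc(-c2cc(-c3cccc(F)c3)cc(-c3cccc(O)c3)n2)cc1` in this assay gives 3070 nM, the only number among the three.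

The cores of compound 1 and compound 3 differ by 3-hydroxyphenyl in place of 2-hydroxyphenyl on an aromatic carbon. That change brings an at least 16-fold lower number from compound 1 to compound 3 (1.21 log units; beyond the scatter). Between compound 1 and compound 2 the change is 4-fluorophenyl in place of 3-fluorophenyl on an aromatic carbon, and its step is a step that the two limits leave unreadable from compound 1 to compound 2 because both values sit at the limit of > 50000 nM in this assay, at which 2 of the 3 values shown sit.

Compound 4 `Oc1ccc(-c2cc(-c3ccc(F)cc3)cc(-c3cccc(O)c3)n2)cc1` has not yet been measured. It differs from compound 3 by 4-fluorophenyl in place of 3-fluorophenyl on an aromatic carbon. This is the same kind of change as that from compound 1 to compound 2, though the surroundings differ: there the place was meta to a 2-hydroxyphenyl group, here it is meta to a 3-hydroxyphenyl group. The earlier instance gives no readable size, so the expectation rests on the value of compound 3 3070 nM alone: the step from compound 3 to compound 4 is expected to be a 1.1-fold higher number from compound 3 to compound 4 (0.06 log units; within the scatter). Compound 4 is estimated at 3500 nM in this assay, expected to fall between 1200 nM and 12000 nM.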

Compound 4, half-maximal inhibitory concentration: 5020 nM
Estimate against measurement, compound 4: 1.4-fold (0.16 log units) below, within the range that was stated.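

In this assay, 3-hydroxyphenyl in place of 2-hydroxyphenyl brings an at least 9.9-fold lower number from compound 2 to compound 4 (0.99 log units; beyond the scatter), while 4-fluorophenyl in place of 3-fluorophenyl brings a 1.6-fold higher number from compound 3 to compound 4 (0.21 log units; within the scatter). The hydroxyphenyl change thus goes the same way on both cores, so in these two pairs it carries from one core to the other in direction: the same change on two cores in this assay, an at least 16-fold lower number (1.21 log units; beyond the scatter) from compound 1 to compound 3 and an at least 9.9-fold lower number (0.99 log units; beyond the scatter) from compound 2 to compound 4; the limit leaves it open whether they differ What this does not show is the full size of either step, as compound 1 and compound 2 give no number on which to measure it: the limit of > 50000 nM in this assay, at which 2 of the 4 values shown sit.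

The compounds shown leave open whether the hydroxyphenyl step would hold on a core with neither fluorophenyl group, and what a 4-hydroxyphenyl group would give in the place of the 3-hydroxyphenyl group. They also leave open what a methoxy group or an amine would give in place of the hydroxyl group on that ring.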